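The compounds below may be only part of what the source reports. "The series", "measured", "known", "first", "only" and "open" are said of these compounds alone.

Compound 1 `CC(NC(=O)c1ccc(-c2ccc(NC(=O)Nc3cc(C(F)(F)F)ccc3Cl)cc2)cc1)c1ccccc1` gives 6570 nM in a functional assay on HT-29 cells (Homo sapiens) for inhibition, read by MTT assay, with a stated time of 120 h (on this read-out lower numbers stand for stronger inhibition and higher numbers for weaker inhibition), where it stands second highest of the three numbers measured. Compound 2 `CC(NC(=O)c1ccc(-c2ccc(NC(=O)Nc3ccc(Cl)c(C(F)(F)F)c3)cc2)cc1)c1ccccc1` gives 5960 nM, a step of a 1.1-fold lower number from compound 1 to compound 2 (0.04 log units; within the scatter). Compound 3 `CC1CN(C(=O)/C=C/c2ccc(NC(=O)Nc3ccc(Cl)c(C(F)(F)F)c3)cc2)CC(C)O1` gives 9100 nM. Compound 4 `CC1CN(C(=O)c2ccc(-c3ccc(NC(=O)Nc4cc(C(F)(F)F)ccc4Cl)cc3)cc2)CC(C)O1` differs from compound 1 at the carbonyl carbon: 2,6-dimethylmorpholin-4-yl in place of (1-phenylethyl)amino on a carbonyl carbon. Among the compounds with values here, no measured step covers this exact change; the single measured step concerns the aryl urea end and lay within the scatter, while compound 3 carries the entering group on another core and gives 9100 nM. A step of no more than the scatter is therefore expected, giving a 1.1-fold higher number from compound 1 to compound 4 (0.03 log units; within the scatter). Compound 4 is estimated at 7000 nM, within 3000 nM to 16000 nM.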

Compound 4, half-maximal inhibitory concentration: 1900 nM
For compound 4 the middle estimate is 3.7-fold (0.57 log units) above the measured one; the measured number lies below the stated range.
By their numbers in this assay, from the lowest: compound 4; then compounds 2, 1 and 3 (each within the scatter of the next).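

At the carbonyl carbon of the shared core, 2,6-dimethylmorpholin-4-yl in place of (1-phenylethyl)amino gives a 3.5-fold lower number from compound 1 to compound 4 (0.54 log units; beyond the scatter) in this assay and is the first step shown to lie beyond the scatter, whereas the step at the aryl urea end stayed within it. The change removes both the amide hydrogen and the aromatic ring of the leaving group, and the compounds shown do not separate these two differences. No measurement at hand accounts for the step. From the compounds shown here alone, whether an unsubstituted morpholine or a piperidine on this carbonyl carbon would give a similar number remains open, as does whether the step carries over to the 4-chloro-3-(trifluoromethyl)phenyl urea of compound 2.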